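The source may hold more compounds than are shown below. What is called first, only, known or untested is meant among the compounds shown, and "the series" means these compounds.

Compound 1 `N=C(NO)N/N=C/c1ccc(Cl)cc1` carries a chloro group and was tested in an ADME assay on HeLa cells (Homo sapiens) for cytotoxicity; a higher number here means that more compound is tolerated, a lower number that less compound is tolerated. In that test compound 1 gives > 100000 nM, which is a limit of the assay rather than a measured number. A second compound, compound 2 `COc1ccccc1/C=N/N=C(\N)NO`, gives > 100000 nM, again only a limit. Both values sit at the limit of > 100000 nM in this assay, at which 2 of the 2 values shown sit, so compound 1 stands at the ceiling of what has been seen. Compound 3 `N=C(NO)N/N=C/c1ccccc1` differs from compound 1 by hydrogen in place of chloro on an aromatic carbon. With compound 1 and compound 2 both at the limit of > 100000 nM in this assay, at which 2 of the 2 values shown sit, no shift beyond the scatter is expected in this assay. The expected step that the limit leaves unreadable from compound 1 to compound 3 is essentially none. Compound 3 is thus estimated at 150000 nM, with a range from 70000 nM to 400000 nM.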

Compound 3, half-maximal cytotoxic concentration: > 100000 nM
Compound 3: no number, only a limit; the forecaster's own chance of this, stated with the estimate: 85%; the middle value does not contradict the limit.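

Compound 1 and compound 3 both give only a limit in this assay, so no step can be read between them: the limit of > 100000 nM in this assay, at which 3 of the 3 values shown sit. The compounds shown leave open at what concentration any of them harms the cells, and whether hydrogen in place of chloro alters that.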